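A few compounds are considered here, and "the series" means these few. Any claim that something is new, unique, unknown or untested is made for them only; others in the source may bear on it.

Compound 1, with the structure `CC(C)S(=O)(=O)c1ccccc1NCC1=NCCN1`, carries an isopropylsulfonyl group on the shared core. In a functional assay for agonist activity at Alpha-1B adrenergic receptor (Homo sapiens) (a higher number here means that more compound is needed for the effect, a lower number that less compound is needed), compound 1 returns only a limit, < 10000 nM, so its exact potency is not pinned down. Compound 2, with the structure `CS(=O)(=O)c1ccc(Cl)cc1NCC1=NCCN1`, is a related analogue; in this assay compound 2 gives 61.7 nM, a measured number rather than a limit. Compound 3, with the structure `CCS(=O)(=O)c1ccccc1NCC1=NCCN1`, differs from compound 1 in one place: hydrogen in place of methyl on a saturated chain carbon bound to a saturated chain carbon and a sulfonyl sulfur, so the isopropylsulfonyl becomes an ethylsulfonyl. For the measured compounds named here, no measured pair here shows what such a change does, and the only footing for compound 1 is the limit (the limit of < 10000 nM in this assay, at which 1 of the 2 values shown sits). The step from compound 1 to compound 3 is therefore expected to be small, and the expected step that the limit leaves unreadable from compound 1 to compound 3 could fall in either direction. For compound 3 the expected value in this assay is 2000 nM, with a likely range from 300 nM to 9000 nM.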

Compound 3, half-maximal effective concentration: < 100000 nM
Compound 3 was reported as a limit; the forecaster's own chance of this, stated with the estimate: 40%; the middle value does not contradict the limit.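

Compound 1 and compound 3 are both reported only as limits in this assay, so the step between them, isopropylsulfonyl to ethylsulfonyl, cannot be read. The compounds shown leave open how potent compound 1 and compound 3 actually are, and whether this change shifts potency at all.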